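From methylamino to amino: one more methyl goes

A few compounds are considered here, and "the series" means these few. Any claim that something is new, unique, unknown or untested is made for them only; others in the source may bear on it.

Compound 1 `CN(C)c1ncnc2[nH]cc(Sc3cccs3)c12` and compound 2 `CNc1ncnc2[nH]cc(Sc3cccs3)c12` share a core and were both measured in a functional assay on HL-60 cells (Homo sapiens) for cytotoxicity, read by XTT assay, with a stated time of 6 days; a higher number here means a weaker inhibitor, a lower number a stronger inhibitor. Compound 1 reaches only a limit of the assay, > 25000 nM. For the measured compounds named here, compound 2 gives 13500 nM, the only true number available.

Compound 3 `Nc1ncnc2[nH]cc(Sc3cccs3)c12` differs from compound 2 by a single change, (hydrogen in place of methyl on a nitrogen on an aromatic ring). The methylamino group becomes amino, with hydrogen in place of methyl on a nitrogen on an aromatic ring.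

Just one measured step involves the same swap, an at least 1.8-fold lower number from compound 1 to compound 2 (0.26 log units; that floor lies within the scatter). It starts from a limit, so it gives a floor rather than a true size, and this floor lies within the scatter. It is therefore weak evidence, though it points toward a lower number in this assay. The expected change is small and may not exceed the scatter, with the estimated step being a 1.7-fold lower number from compound 2 to compound 3 (0.23 log units; within the scatter). For compound 3 the estimated value is 8000 nM, with an expected range from 2500 nM to 25000 nM.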

Compound 3, half-maximal inhibitory concentration: 13900 nM
The estimate for compound 3 lay 1.7-fold (0.24 log units) below the measured number; measured number inside the range.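

In this assay, the change from methylamino to amino now has a true size, measured between two real numbers (a 1.0-fold higher number from compound 2 to compound 3 (0.01 log units; within the scatter)), and that size lies within the scatter. The earlier step offered only a floor, and the same holds for the step that removes both methyl groups (an at least 1.7-fold lower number from compound 1 to compound 3 (0.25 log units; that floor lies within the scatter)), which also starts from a limit and so gives no true size. Compound 2 and compound 3 therefore show that, on this nitrogen, losing the last methyl leaves the number in place, while the true distance of compound 1 from either of them cannot be read: the limit of > 25000 nM in this assay, at which 1 of the 3 values shown sits.

The compounds shown carry only dimethylamino, methylamino and amino on this aromatic carbon, which leaves open whether a longer chain such as ethylamino, or a cyclic amine such as morpholine, would move the number beyond the scatter. Going by these compounds, it is also open whether the methylamino to amino change would stay as small with a phenyl group on the sulfur of the shared core in place of its present ring.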